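The source may hold more compounds than are shown below. What is called first, only, known or untested is meant among the compounds shown, and "the series" means these compounds.

Compound 1, `CC1=CC[C@]2(C)[C@@H]([C@@H](OC(=O)c3ccc(O)cc3)C1)[C@](O)(C(C)C)C[C@@H]2O`: 22400 nM
Compound 2, `C=C1C[C@H](OC(=O)c2ccc(O)cc2)[C@@H]2[C@](C)(CC[C@@]2(O)C(C)C)C[C@@H]1O`: 34700 nM
Compound 3, `COc1ccc(C(=O)OCC2=CC[C@@]3(C)CC[C@]4(C(C)C)O[C@]34CC2)cc1`: 84000 nM

These three compounds were tested in a functional assay on SEM cells (Homo sapiens) for cytotoxicity, read by MTT assay, with a stated time of 72 h; a lower number here means a stronger inhibitor, a higher number a weaker inhibitor. Compound 1 has the lowest number of the three. Compound 2 lies within the usual scatter of compound 1, so the two cannot be told apart, while compound 3 lies beyond the scatter and is the weaker inhibitor of that pair. Compound 4, `CC1=CC[C@@]2(C)CC[C@@](O)(C(C)C)[C@@H]2[C@@H](OC(=O)c2ccc(O)cc2)C1`, has not yet been measured in this assay. It differs from compound 1 in one place: hydrogen in place of hydroxy on a saturated ring carbon. Going by the values given here, no pair of measured compounds shows what this change does on its own, so the expectation rests only on the values at hand and on the small size of the change, which removes a single hydroxy group from the core. A modest shift is expected, toward a weaker inhibitor if anything, and most likely not beyond the scatter around compound 1. The expected change is a 1.3-fold higher number from compound 1 to compound 4 (0.13 log units; within the scatter). Compound 4 is therefore estimated to give 30000 nM, with a likely range from 12000 nM to 75000 nM.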

Compound 4, half-maximal inhibitory concentration: > 100000 nM
Compound 4: no number, only a limit (the forecaster's own chance of this, stated with the estimate: 10%); middle value at least 3.3-fold (0.52 log units) away from the limit.
By their numbers in this assay, from the lowest: compounds 1 and 2 (each within the scatter of the next); then compound 3. At a limit, above all of these: compound 4.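

In this assay, replacing the hydroxy group on this saturated ring carbon with hydrogen gives an at least 4.4-fold higher number from compound 1 to compound 4 (0.64 log units; beyond the scatter), the first direct view of this position, and the step lies beyond the scatter. The earlier compounds shown here showed no single change, whereas this pair shows that the activity of compound 1, weak as it is, depends on this one hydroxy group. Compound 4 gives > 100000 nM, which is a limit of the assay and not a number, so the full size of the step stays unknown: the limit of > 100000 nM in this assay, at which 1 of the 4 values shown sits.

From the compounds shown here alone, whether the hydroxy group itself is required remains open, since a methoxy group, an amine or a fluorine atom on this carbon could behave differently. Also open, going by these compounds, is whether a hydroxy group of the opposite orientation on this carbon would serve equally well.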